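Dechlorination of the hydrazone aryl ring: compound 3

The compounds below may be only part of what the source reports. "The series", "measured", "known", "first", "only" and "open" are said of these compounds alone.

Measured compounds:
compound 1 `COc1ccc(OC)c(/C=C/c2nnc(Nc3ccc(Cl)cc3)o2)c1`: 28300 nM
compound 2 `COc1ccc(OC)c(/C=C/C(=O)N/N=C/c2ccc(Cl)cc2)c1`: 1520 nM

Among the measured compounds shown here, in a functional assay on HT-29 cells (Homo sapiens) for antiproliferative activity, read by sulforhodamine B assay, with a stated time of 48 h (on this read-out lower numbers stand for stronger inhibition of growth and higher numbers for weaker inhibition of growth), compound 2 gives 1520 nM, the lowest of the two numbers so far. Compound 1 gives 28300 nM, a gap beyond the scatter, so compound 2 is the clear reference point for the next step. For the measured compounds named here, no pair of measured compounds differs in a single place, so no measured step is available to calibrate what follows.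

Compound 3 `COc1ccc(OC)c(/C=C/C(=O)N/N=C/c2ccccc2)c1` is not yet measured. It differs from compound 2 by hydrogen in place of chloro on an aromatic carbon. The data give nothing on a chloro-to-hydrogen exchange at this place, so the size of the step rests on expectation alone. The step of a 2.3-fold higher number from compound 2 to compound 3 (0.36 log units; beyond the scatter) is expected to be small, in the direction of weaker inhibition of growth, and may not clear the scatter. Compound 3 is expected at about 3500 nM, within a range from 1200 nM to 10000 nM.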

Compound 3, concentration for total growth inhibition: > 100000 nM
Compound 3: a limit, no number; the forecaster's own chance of this, stated with the estimate: 5%; at least 28-fold (1.45 log units) between middle value and limit.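

In this assay, among the compounds shown here, replacing the chloro group with hydrogen gives an at least 65-fold higher number from compound 2 to compound 3 (1.81 log units; beyond the scatter), the first single-place step and a large one. For compound 3, the value > 100000 nM is a limit of the assay and not a number: the limit of > 100000 nM in this assay, at which 1 of the 3 values shown sits. This shows that growth inhibition on this read-out depends heavily on the chloro group at this aromatic carbon, para to a large group, so the 4-chlorophenyl to phenyl change cannot be treated as a minor edit in this hydrazone.

The compounds shown leave open whether fluoro, bromo, methoxy or an amine at this place would match the chloro group of compound 2. They also leave open whether the same change would weigh as heavily on the core of compound 1.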